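The source may hold more compounds than are shown below. What is called first, only, known or untested is meant among the compounds shown, and "the series" means these compounds.

Compound 3 `O=C1Nc2ccc(-c3ccco3)cc2/C1=C/c1cc(Cl)c(O)c(Cl)c1` stands highest of the three measured compounds in an assay on HeLa cells for inhibition of Kinesin-like protein KIF15 (Homo sapiens), read by microscopy, with stated times of 2 s and 20 s, tested at 750 nM (a higher number here means more inhibition at the concentration tested (going by the name of the read-out), a lower number less inhibition), where compound 3 gives 33%; compound 2 `CN(C)C(=O)c1ccc2c(c1)/C(=C/c1cc(Cl)c(O)c(Cl)c1)C(=O)N2` gives 15.3% and compound 1 `O=C1Nc2ccc(C(=O)NCc3ccccc3)cc2/C1=C/c1cc(Cl)c(O)c(Cl)c1` gives -24%. The change leading to compound 4 `O=C1Nc2ccc(-c3cccc(F)c3)cc2/C1=C/c1cc(Cl)c(O)c(Cl)c1` is 3-fluorophenyl in place of furan-2-yl on an aromatic carbon. Among the measured compounds shown here, no measured step swaps one aromatic ring for another; the nearest are a number 57 percentage points higher from compound 1 to compound 3 (beyond the scatter) and a number 17.7 percentage points higher from compound 2 to compound 3 (beyond the scatter), both large gains in which furan-2-yl replaced a carbamoyl group. Those gains concern the loss of a carbamoyl group, not an exchange between two rings, so they set no size for this change. A step within the scatter is therefore expected, a number 3 percentage points lower from compound 3 to compound 4 (within the scatter). Compound 4 is estimated at 30%, with a range from -5% to 60%.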

Compound 4, a percentage reported as inhibition, at one concentration (the size of the read-out at that concentration, not a potency): -5.8%
Compound 4: middle estimate off by 35.8 percentage points, on the high side; the whole stated range lies above it.
By their numbers in this assay, from the lowest: compound 1; then compound 4; then compound 2; then compound 3.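

In this assay this position does not accept any aromatic ring equally, since 3-fluorophenyl in place of furan-2-yl gives a number 38.8 percentage points lower from compound 3 to compound 4 (beyond the scatter) here. An aromatic ring alone therefore does not secure the higher numbers, as the same ring in place of dimethylcarbamoyl gives a number 21.1 percentage points lower from compound 2 to compound 4 (beyond the scatter) while in place of benzylcarbamoyl it gives a number 18.2 percentage points higher from compound 1 to compound 4 (beyond the scatter) and so still improves on that amide. No measured evidence here accounts for the fall.

On these data alone, whether the fall belongs to the fluorine or to the six-membered ring stays open, and an unsubstituted phenyl ring would separate the two. A thiophene ring or a small amine at this position would show how far the furan-2-yl result extends.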